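Longer thioether chains in a chloromethyl ketone series

The source may report more compounds than this note shows. Statements on the series, on what has been measured and on what is new or still open speak of the compounds shown alone.

In a functional assay on MOLT-3 cells (Homo sapiens) (on this read-out higher numbers stand for weaker inhibition and lower numbers for stronger inhibition), three compounds have been measured:
compound 1, `CCCCCCCCCCSC[C@H](NC(C)=O)C(=O)CCl`: compound 1 gives 3400 nM
compound 2, `CCCCCCCCCCCCCSC[C@H](NC(C)=O)C(=O)CCl`: compound 2 reaches only the assay limit of > 100000 nM
compound 3, `CCCCCCCCCCCCCCCCSC[C@H](NC(C)=O)C(=O)CCl`: compound 3 gives 17300 nM

Compound 3 holds the highest of the two plain numbers; its nearest neighbour is compound 1, and a 5.1-fold higher number from compound 1 to compound 3 (0.71 log units; beyond the scatter). Compound 2 sits at the limit (the limit of > 100000 nM in this assay, at which 1 of the 3 values shown sits). Compound 4, `CCCCCCCCCCCCCCCCCCCCSC[C@H](NC(C)=O)C(=O)CCl`, differs from compound 3 by butyl in place of hydrogen on a saturated chain carbon, ten or more bonds along the chain from a sulfur. Within the data shown here, the steps that bear on this are a 5.1-fold higher number from compound 1 to compound 3 (0.71 log units; beyond the scatter) and an at least 29-fold higher number from compound 1 to compound 2 (1.46 log units; beyond the scatter), both lengthening the chain and both raising the number, whereas an at least 5.7-fold lower number from compound 2 to compound 3 (0.76 log units; beyond the scatter) runs the other way but starts from a limit. A further rise, modest to large, is therefore expected: a 2.6-fold higher number from compound 3 to compound 4 (0.42 log units; beyond the scatter). Compound 4 is estimated at 45000 nM, between 12000 nM and 150000 nM.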

Compound 4, half-maximal inhibitory concentration: > 100000 nM
Compound 4: only a limit was reported; the forecaster's own chance of this, stated with the estimate: 35%; middle value at least 2.2-fold (0.34 log units) from the limit.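

Compound 4 gives a limit, not a number: the limit of > 100000 nM in this assay, at which 2 of the 4 values shown sit. Adding butyl in place of hydrogen on a saturated chain carbon, ten or more bonds along the chain from a sulfur, gives an at least 5.7-fold higher number from compound 3 to compound 4 (0.76 log units; beyond the scatter), and the longest chain stays well off compound 1, with an at least 29-fold higher number from compound 1 to compound 4 (1.46 log units; beyond the scatter). Compound 3 now stands as the only one of the three longer chains with a plain number, against a simple rise with length, and the step between the two limits cannot be read.

On these data alone, whether a shorter chain than that of compound 1 would lower the number remains open. So does the effect of an amine or a carboxylic acid on a saturated chain carbon.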